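The source may hold more compounds than are shown below. What is called first, only, known or untested is meant among the compounds shown, and "the series" means these compounds.

Working notes on the series. In a functional assay on PC-3 cells (Homo sapiens) for inhibition, read by MTT assay, with a stated time of 72 h, tested at 10 uM (on this read-out higher numbers stand for more inhibition of growth at the one concentration tested and lower numbers for less inhibition of growth), compound 1 `O=C(/C=C/c1ccc(Oc2ncnc3ccc(Cl)cc23)cc1)/C=C/c1cc([N+](=O)[O-])ccc1Cl` gives 76.8%. Compound 2 `O=C(/C=C/c1ccc(Oc2ncnc3ccc(Cl)cc23)cc1)/C=C/c1c(Cl)cccc1Cl` gives 67.5%. Compound 3 `O=C(/C=C/c1ccc(Cl)c([N+](=O)[O-])c1)/C=C/c1ccccc1Oc1ncnc2ccc(Cl)cc12` gives 62.5%. On these numbers compound 2 sits between compound 1 and compound 3, and both gaps are within the usual scatter, so no ranking among the three can be drawn.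

Compound 4 `O=C(/C=C/c1ccc(Oc2ncnc3ccc(Cl)cc23)cc1)/C=C/c1ccc(Cl)c([N+](=O)[O-])c1` is not yet measured. It differs from compound 2 by 4-chloro-3-nitrophenyl in place of 2,6-dichlorophenyl on a double-bonded chain carbon bound to a double-bonded chain carbon. Among the measured compounds shown here, the one measured step at the same place, a number 9.3 percentage points lower from compound 1 to compound 2 (within the scatter), exchanged a chloro- and nitro-bearing phenyl for the dichlorophenyl and stayed within the scatter. For the measured compounds named here, compound 3 carries the same 4-chloro-3-nitrophenyl that enters in compound 4, but with the rest of the molecule arranged differently, so no step to it is computed; its value and that of compound 2 lie within the scatter of each other. Nothing here points to a move beyond the scatter in this assay for the change to compound 4, and the expected step of a number 3.5 percentage points higher from compound 2 to compound 4 (within the scatter) is therefore small. Compound 4 is expected to give about 71%, with a range of 58% to 84%.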

Compound 4, percent growth inhibition at one concentration: 56.3%
Compound 4: the middle estimate sits 14.7 percentage points above what was measured, and the stated range ends above it.
By their numbers in this assay, from the lowest: compounds 4, 3, 2 and 1 (each within the scatter of the next, the first and the last beyond it).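

In this assay, the place on a double-bonded chain carbon bound to a double-bonded chain carbon now shows steps beyond the scatter: a number 11.2 percentage points lower from compound 2 to compound 4 (beyond the scatter) and a number 20.5 percentage points lower from compound 1 to compound 4 (beyond the scatter). The second step only exchanges 2-chloro-5-nitrophenyl for 4-chloro-3-nitrophenyl, so at this place the read-out depends on where the chloro and nitro groups stand on the phenyl ring, not merely on their presence, which the earlier step between compound 1 and compound 2 did not show. Nothing on hand accounts for this difference.

The compounds shown leave open how a phenyl ring carrying an amine or a carboxylic acid would read at this place. They also leave open whether the same order of compound 4, compound 2 and compound 1 holds at other concentrations.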